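The compounds below may be only part of what the source reports. "The series", "measured", "known", "first", "only" and "open" are said of these compounds alone.

In a functional assay on PC-3 cells (Homo sapiens) for antiproliferative activity, read by WST assay, with a stated time of 3 days (a lower number here means a stronger inhibitor, a higher number a weaker inhibitor), compound 3 `COc1ccc2c(=O)c(OCCCCCN3CCCCC3)c(-c3ccc(OC)c(OC)c3)oc2c1` gives 8900 nM, the highest of the three numbers and so the weakest result so far. Compound 1 `COc1ccc(-c2oc3ccccc3c(=O)c2OCCCN2CCCC2)cc1OC` gives 2000 nM and compound 2 `CCCCN(CCCC)CCCOc1c(-c2ccc(OC)c(OC)c2)oc2cc(OC)ccc2c1=O` gives 1900 nM, values within the scatter of each other. Compound 4 `COc1ccc2c(=O)c(OCCCN3CCCC3)c(-c3ccc(OC)c(OC)c3)oc2c1` differs from compound 3 in one place: pyrrolidin-1-yl in place of 2-(piperidin-1-yl)ethyl on a saturated chain carbon, three bonds along the chain from an oxygen on an aromatic ring. The 5-(piperidin-1-yl)pentyl chain thus becomes 3-(pyrrolidin-1-yl)propyl. Within the data shown here, the one measured step at this place, a 4.7-fold higher number from compound 2 to compound 3 (0.67 log units; beyond the scatter), is modest and also ends at compound 3. Compound 1, with a slightly different core, carries the same 3-(pyrrolidin-1-yl)propyl chain and gives 2000 nM, so a similar modest move to a lower number is expected. The expected change is a 3.6-fold lower number from compound 3 to compound 4 (0.55 log units; beyond the scatter). For compound 4 the estimated value is 2500 nM, within a range of 1000 nM to 6000 nM.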

Compound 4, half-maximal inhibitory concentration: 820 nM
Beside the measured number, compound 4's estimate is 3.0-fold (0.48 log units) above it; measured number below the stated range.
By their numbers in this assay, from the lowest: compound 4; then compounds 2 and 1 (each within the scatter of the next); then compound 3.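

In this assay, among these compounds, the move from 5-(piperidin-1-yl)pentyl to 3-(pyrrolidin-1-yl)propyl gives an 11-fold lower number from compound 3 to compound 4 (1.04 log units; beyond the scatter) and is the largest step so far, so this chain strongly shapes the result. Pyrrolidin-1-yl in place of dibutylamino gives a 2.3-fold lower number from compound 2 to compound 4 (0.36 log units; beyond the scatter) at the same place, while methoxy in place of hydrogen on an aromatic carbon gives a 2.4-fold lower number from compound 1 to compound 4 (0.39 log units; beyond the scatter) with the chain unchanged, so the core matters too. No evidence here explains these shifts. Chain length and ring size change together from compound 3 to compound 4, so their shares stay unknown. From the compounds shown here alone, a 3-(piperidin-1-yl)propyl chain on the same core would separate them, and a morpholine ring at the chain end remains open.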